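The source may hold more compounds than are shown below. What is called first, only, known or untested is meant among the compounds shown, and "the series" means these compounds.

In a functional assay on SK-MEL-5 cells (Homo sapiens) for antiproliferative activity, read by sulforhodamine B assay, with a stated time of 48 h (a higher number here means a weaker inhibitor, a lower number a stronger inhibitor), two compounds sharing one core have been measured. Compound 1 `O=C(Nc1ccc(-n2cc(-c3ccncc3)c(-c3ccc(Cl)c(O)c3)n2)cc1)c1ccc(Cl)c(Cl)c1` gives 1150 nM, and compound 2 `O=C(Nc1ccc(-n2cc(-c3ccncc3)c(-c3ccc(Cl)c(O)c3)n2)cc1)c1cc(Cl)cc(Cl)c1` gives 1400 nM. Going by the values given here, compound 2 has the higher of the two numbers, but the one step that separates them, a 1.2-fold higher number from compound 1 to compound 2 (0.09 log units; within the scatter), lies within the scatter, so neither compound can be called the stronger inhibitor on these numbers alone.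

Compound 3 `O=C(Nc1ccc(-n2cc(-c3ccncc3)c(-c3ccc(Cl)c(O)c3)n2)cc1)c1ccc(Cl)c(C(F)(F)F)c1` is not yet measured. It differs from compound 2 in one place: 4-chloro-3-(trifluoromethyl)phenyl in place of 3,5-dichlorophenyl on a carbonyl carbon. Among the compounds with values here, the only measured step that bears on this change is the exchange of one dichlorophenyl pattern for another on the same carbonyl carbon, a 1.2-fold higher number from compound 1 to compound 2 (0.09 log units; within the scatter), which stayed within the scatter. The change to compound 3 again replaces the aryl group on that carbonyl carbon while leaving the rest of the molecule untouched, so a step of similar size is expected, with no clear direction beyond the scatter: a 1.2-fold lower number from compound 2 to compound 3 (0.07 log units; within the scatter) is the expected movement. Compound 3 is therefore estimated at 1200 nM in this assay, with a range from 500 nM to 2800 nM.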

Compound 3, half-maximal inhibitory concentration: 1070 nM
Compound 3: the middle estimate sits 1.1-fold (0.05 log units) above what was measured; the measured number falls inside the stated range.
By their numbers in this assay, from the lowest: compounds 3, 1 and 2 (each within the scatter of the next).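

In this assay, replacing a dichlorophenyl on the carbonyl carbon with a group that carries trifluoromethyl does not produce a step beyond the scatter: the change from 3,5-dichlorophenyl to 4-chloro-3-(trifluoromethyl)phenyl gives a 1.3-fold lower number from compound 2 to compound 3 (0.12 log units; within the scatter). The narrower exchange of trifluoromethyl in place of chloro on an aromatic carbon gives a 1.1-fold lower number from compound 1 to compound 3 (0.03 log units; within the scatter), which also lies within the scatter, so this single exchange leaves the read-out unresolved from that of the chlorine-bearing compound 1. Across the three aryl groups now shown at this position, every printed step stays within the scatter, and nothing measured here bears on why they read alike.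

The compounds shown leave open whether the same holds for a ring on this carbonyl carbon that carries an amine or a carboxylic acid, or for a plain phenyl with no substituent at all. They also leave open what a change elsewhere would do, as all three compounds keep the rest of the molecule, including the amide nitrogen and the shared core, the same.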